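This account rests on a few compounds, and the source may have more. Where it says the series, first, only, none or still open, it means among the compounds named here.

The measured compounds in an assay on cells for inhibition of S-adenosylmethionine decarboxylase proenzyme (Homo sapiens), read by mass spectrometry, at pH 7.2; a higher number here means a weaker inhibitor, a lower number a stronger inhibitor:
- compound 1, `COc1ccc(-c2cc(Cl)cc(Nc3cc(C)nc(N)n3)c2)cc1`, which gives only a limit, > 180000 nM.
- compound 2, `Cc1ccc(-c2cc(Cl)cc(Nc3cc(C)nc(N)n3)c2)cc1`, which gives only a limit, > 63000 nM.
- compound 3, `Cc1cc(Nc2cc(Cl)cc(-c3ccc(C#N)cc3)c2)nc(N)n1`, which gives only a limit, > 7000 nM.

Compound 3 therefore stands on a limit alone, and the two other values shown are limits as well, so no number places it among them.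

Compound 4, `CC(=O)c1ccc(-c2cc(Cl)cc(Nc3cc(C)nc(N)n3)c2)cc1`, differs from compound 3 in one place: acetyl in place of cyano on an aromatic carbon. Among the measured compounds shown here, the steps that bear on this change are those that swap the group on the same aromatic carbon: a step that the two limits leave unreadable from compound 2 to compound 3, a step that the two limits leave unreadable from compound 1 to compound 3 and a step that the two limits leave unreadable from compound 1 to compound 2. None of them has a readable size, so no direction can be drawn from them. Compound 4 is expected to give 60000 nM, in the range 7000 nM to 300000 nM. The step from compound 3 to compound 4 is accordingly estimated at a step that the limit leaves unreadable from compound 3 to compound 4, most probably again only a limit.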

Compound 4, half-maximal inhibitory concentration: > 21000 nM
Compound 4: no number, only a limit (the forecaster's own chance of this, stated with the estimate: 75%); the middle value does not contradict the limit.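

In this assay compound 4 gives only a limit, > 21000 nM, so the steps to it from compound 1, compound 2 and compound 3 cannot be read. The compounds shown leave open how methoxy, methyl, cyano and acetyl rank on this aromatic carbon.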